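The source may hold more compounds than are shown below. What is called first, only, known or untested is meant among the compounds shown, and "the series" means these compounds.

Measured so far:
compound 1 `COc1ccc2nc(C)cc(NCc3ccc(F)c(F)c3)c2c1` gives 12000 nM
compound 2 `COc1ccc2nc(C)cc(NCc3ccc(F)cc3F)c2c1` gives 15000 nM
compound 3 `COc1ccc2nc(C)cc(NCc3ccc(F)c(C(F)(F)F)c3)c2c1` gives 14300 nM

All three values come from a functional assay on MCF-10A cells (Homo sapiens) for antiproliferative activity, with a stated time of 48 h; on this read-out lower numbers stand for an effect already at smaller amounts and higher numbers for an effect only at larger amounts of compound. Compound 3 differs from compound 1 by trifluoromethyl in place of fluoro on an aromatic carbon, and that change gave a 1.2-fold higher number from compound 1 to compound 3 (0.08 log units; within the scatter). Compound 2 has the same atoms as compound 1, joined differently; the difference between the two cores is not broken down here. The unmeasured compound 4 `COc1ccc2nc(C)cc(NCc3ccc(F)cc3C(F)(F)F)c2c1` differs from compound 2 by trifluoromethyl in place of fluoro on an aromatic carbon. Among the compounds with values here, this is the same kind of change as the one from compound 1 to compound 3, but not the same: there the entering group sits ortho to a fluoro group and meta to a large group, here it sits ortho to a large group and meta to a fluoro group. Because a 1.2-fold higher number from compound 1 to compound 3 (0.08 log units; within the scatter) stayed within the scatter, the step from compound 2 to compound 4 is expected to be small as well, a 1.2-fold higher number from compound 2 to compound 4 (0.08 log units; within the scatter). For compound 4 the expected value in this assay is therefore 18000 nM, estimated to lie between 9000 nM and 36000 nM.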

Compound 4, half-maximal effective concentration: 4200 nM
Compound 4: middle estimate off by 4.3-fold (0.63 log units), on the high side, and the stated range ends above it.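

In this assay, putting trifluoromethyl in place of fluoro gave a 3.6-fold lower number from compound 2 to compound 4 (0.55 log units; beyond the scatter), so this change did not carry over with the same result from one core to the other: the same change on two cores in this assay, a 1.2-fold higher number (0.08 log units; within the scatter) from compound 1 to compound 3 and a 3.6-fold lower number (0.55 log units; beyond the scatter) from compound 2 to compound 4, 4.3-fold (0.63 log units) apart, beyond the scatter of two such steps The result of this swap in the series therefore cannot be taken from one core and assumed for another. Within the data shown here, with only one pair on each core, these data do not show why the two steps differ, nor which feature of the two cores matters.

On these data alone, it remains open whether a different group in the same place as the trifluoromethyl of compound 4, such as a nitrile or an amine, would also give a lower number than compound 2.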